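Benzoyl to cyano at the limit of the assay

The source may hold more compounds than are shown below. What is called first, only, known or untested is meant among the compounds shown, and "the series" means these compounds.

Values in a functional assay on Raji cells (Homo sapiens) for cytotoxicity, with a stated time of 72 h (on this read-out higher numbers stand for an effect only at larger amounts of compound and lower numbers for an effect already at smaller amounts), each one a limit:
- compound 1 `C=C[C@@](C)(/C=C/c1ccc(O)c(CO)c1)CCC=C(C)C`: > 26000 nM
- compound 2 `C=C[C@@](C)(/C=C/c1ccc(O)c(C=O)c1)CCC=C(C)C`: > 26000 nM
- compound 3 `C=C[C@@](C)(/C=C/c1ccc(O)c(/C=C/C(=O)c2ccccc2)c1)CCC=C(C)C`: > 26000 nM

Compound 3 gives no number, and its > 26000 nM is a limit. The whole series shows the same picture: the limit of > 26000 nM in this assay, at which 3 of the 3 values shown sit.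

Compound 4 `C=C[C@@](C)(/C=C/c1ccc(O)c(/C=C/C#N)c1)CCC=C(C)C` keeps the shared core and changes one group: cyano in place of benzoyl on a double-bonded chain carbon bound to a double-bonded chain carbon.

For the measured compounds named here, no measured step involves this change. The only one, a step that the two limits leave unreadable from compound 1 to compound 2, swaps hydroxymethyl for formyl, and it gives no guide to size or direction. With the limit of > 26000 nM in this assay, at which 3 of the 3 values shown sit, compound 4 is expected to show no clear gain in this assay and will most likely also return only a limit.

The expected step is a step that the limit leaves unreadable from compound 3 to compound 4. Compound 4 is estimated at 30000 nM, with an expected range from 13000 nM to 60000 nM.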

Compound 4, half-maximal effective concentration: > 26000 nM
Compound 4: only a limit was reported; the forecaster's own chance of this, stated with the estimate: 80%; the middle value is on the limit's open side.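

For the compounds shown here, no step to compound 4 can be read: compound 4, like compound 1, compound 2 and compound 3, gives only a limit, and neither size nor direction shows. The compounds shown leave open whether any change on the shared core brings a measurable effect in this assay.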